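Swapping methyl for fluoro on a weak antiproliferative core

The source may hold more compounds than are shown below. What is called first, only, known or untested is meant among the compounds shown, and "the series" means these compounds.

Compound 1 `Cc1ccc2nc(Nc3nc(Nc4ccc(S(N)(=O)=O)cc4)ncc3F)sc2c1`: 24500 nM
Compound 2 `Cc1ccc2nc(Nc3nc(Nc4ccc(S(N)(=O)=O)cc4)ncc3C)sc2c1`: > 50000 nM
Compound 3 `COc1ccc2nc(Nc3nc(Nc4ccc(S(N)(=O)=O)cc4)ncc3C)sc2c1`: > 50000 nM

Three compounds were tested in a functional assay on MCF7 cells (Homo sapiens) for antiproliferative activity, read by MTT assay, with a stated time of 48 h; on this read-out higher numbers stand for weaker inhibition and lower numbers for stronger inhibition. Compound 1 gives 24500 nM. Compound 2 reaches only the limit of this assay, > 50000 nM, not a number. Compound 3 likewise stops at the limit, > 50000 nM. Two of the three values sit at that limit (the limit of > 50000 nM in this assay, at which 2 of the 3 values shown sit), so most of the series is barely active here.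

Compound 2 and compound 1 differ by fluoro in place of methyl on an aromatic carbon, and this gave an at least 2.0-fold lower number from compound 2 to compound 1 (0.30 log units; that floor lies within the scatter). Compound 2 and compound 3 differ in their cores by methoxy in place of methyl on an aromatic carbon, a step that reads as a step that the two limits leave unreadable from compound 2 to compound 3 because both sit at the limit.

Compound 4 `COc1ccc2nc(Nc3nc(Nc4ccc(S(N)(=O)=O)cc4)ncc3F)sc2c1` is not yet measured. It differs from compound 3 by fluoro in place of methyl on an aromatic carbon, the same change as from compound 2 to compound 1. The step is therefore expected to be about an at least 1.6-fold lower number from compound 3 to compound 4 (0.22 log units; that floor lies within the scatter), resting on compound 1 and its value 24500 nM. Compound 4 is expected to show 30000 nM, between 10000 nM and 100000 nM, with a fair chance of only a limit.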

Compound 4, half-maximal inhibitory concentration: > 50000 nM
Compound 4: only a limit was reported; the forecaster's own chance of this, stated with the estimate: 40%; middle value at least 1.6-fold (0.22 log units) away from the limit.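

In this assay compound 4 stops at a limit, > 50000 nM, which is not a number. Among the compounds shown here, the step from compound 3 to compound 4 cannot be read, because both compounds sit at the limit, where most of this small series ends up: the limit of > 50000 nM in this assay, at which 3 of the 4 values shown sit. The one readable new step, methoxy in place of methyl on the core that carries fluoro, is an at least 2.0-fold higher number from compound 1 to compound 4 (0.30 log units; that floor lies within the scatter) and so it adds little, which means these compounds neither show that fluoro in place of methyl carries over to the methoxy core nor show that it fails there.

Going by these compounds, only compound 1 has a true number, so the size of the fluoro change on either core stays open. Also open, on these data alone, is whether another group on that six-membered aromatic ring with 2 nitrogen, such as an amine or a longer chain, would bring a value clear of the limit, so that a comparison between cores could be read.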